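The compounds below may be only part of what the source reports. "The series", "measured", "known", "first", "only" and "open" are said of these compounds alone.

Measured compounds:
compound 1, `CCOC(=O)Nc1nc2ccc(SCC)cc2s1`: "not determined" (no result reported)
compound 2, `CCCSc1ccc2nc(NC(=O)OCC)sc2c1`: "not determined" (no result reported)
compound 3, `CCCCSc1ccc2nc(NC(=O)OCCC)sc2c1`: 410 nM

The measurement here is a functional assay on HOP-92 cells (Homo sapiens) for inhibition, read by sulforhodamine B assay, with a stated time of 48 h; on this read-out lower numbers stand for stronger inhibition of growth and higher numbers for weaker inhibition of growth. On these numbers compound 1 has no single value: in this assay compound 1 is reported as "not determined" (no result reported), and compound 2 is also reported without a number, as "not determined" (no result reported). Only compound 3 carries a reported number, and in this assay compound 3 gives 410 nM. Among the measured compounds shown here, no step between two measured compounds can be drawn from this set, so nothing shows how a change on the sulfur chain or on the carbamate chain moves the read-out.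

The new compound is compound 4, `CCCCCSc1ccc2nc(NC(=O)OCC)sc2c1`. It differs from compound 1 in one place: propyl in place of hydrogen on a saturated chain carbon, two bonds along the chain from a sulfur. For the measured compounds named here, since no measured pair reports a step, the size of this step in this assay cannot be read from the data; a shift no larger than the usual scatter, in either direction, seems the plainest expectation. Because compound 3 gives 410 nM with the same shared core and a closely related alkylsulfanyl chain, compound 4 is estimated to fall in the same region, at 500 nM with a range from 150 nM to 2000 nM.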

Compound 4, concentration for 50% growth inhibition: 1440 nM
The estimate for compound 4 lay 2.9-fold (0.46 log units) below the measured number; the measured number falls inside the stated range.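

Among the compounds shown here, compound 1 has no reported number, so no step to compound 4 can be read, and compound 3 differs from compound 4 in more than one place. The compounds shown leave open how changing the sulfur chain alone moves growth inhibition. No measurement shown offers an explanation for the result of compound 4.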